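Removing Fluoro from the Methylsulfonylphenyl Group

The source may hold more compounds than are shown below. What is called first, only, known or untested is meant among the compounds shown, and "the series" means these compounds.

Of the compounds shown here, two have been measured in a functional assay on HEK293 cells for agonist activity at Glucose-dependent insulinotropic receptor (Homo sapiens), read by cAMP accumulation, with a stated time of 60 min; on this read-out lower numbers stand for smaller maximal responses and higher numbers for larger maximal responses. Compound 1 `COc1cc2nc(Nc3ccc(S(C)(=O)=O)cc3F)nc(OCC3CCN(C(=O)OC(C)(C)C)CC3)c2cc1OC` gives 21.3%. Compound 2 `COc1cc2nc(N3CCC4CCC(C3)N4Cc3ccccc3)nc(Nc3ccc(S(C)(=O)=O)cc3)c2cc1OC` gives 23.4%. Compound 1 thus holds the lower of the two numbers, but its gap to compound 2 lies within the scatter, so the two cannot be told apart on this read-out.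

Compound 3 `COc1cc2nc(Nc3ccc(S(C)(=O)=O)cc3)nc(OCC3CCN(C(=O)OC(C)(C)C)CC3)c2cc1OC` has not yet been measured. It differs from compound 1 in one place: hydrogen in place of fluoro on an aromatic carbon. Cut one bond further out, the change reads 2-fluoro-4-(methylsulfonyl)phenyl to 4-(methylsulfonyl)phenyl. Within the data shown here, no measured pair in this set shows this change, so there is no direct step to rest on. Since compound 1 gives 21.3% and compound 2 gives 23.4%, both low responses, a step no larger than the scatter is expected, in either direction. The expected step is a number 2.7 percentage points higher from compound 1 to compound 3 (within the scatter). In this assay compound 3 is estimated to give 24%, with a range from 12% to 38%.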

Compound 3, largest response reached (Emax), in percent of the reference or control that the assay uses: 17.4%
Beside the measured number, compound 3's estimate is 6.6 percentage points above it, within the range that was stated.
By their numbers in this assay, from the lowest: compounds 3, 1 and 2 (each within the scatter of the next).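

Among these compounds, the pair gives the first direct reading of this exchange: with hydrogen in place of fluoro on an aromatic carbon, ortho to a large group and meta to a methylsulfonyl group, this assay shows a number 3.9 percentage points lower from compound 1 to compound 3 (within the scatter). On this read-out, the 2-fluoro-4-(methylsulfonyl)phenyl and 4-(methylsulfonyl)phenyl compounds therefore cannot be told apart, and both remain low responses. Nothing available here offers an explanation for this result.

What the compounds shown leave open is whether chloro, methoxy or an amine on this same aromatic carbon would give a response that stands clear of the scatter. Also open, going by these compounds, is whether exchanging fluoro for hydrogen would read the same way on a compound carrying the substituents of compound 2.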